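A few compounds are considered here, and "the series" means these few. Any claim that something is new, unique, unknown or untested is made for them only; others in the source may bear on it.

Measured in an ADME assay on Vero cells (Chlorocebus sabaeus) for cytotoxicity, read by MTT assay, with a stated time of 48 h; on this read-out higher numbers stand for weaker inhibition and lower numbers for stronger inhibition:
compound 1 `O=C(OC1CCC(CN2CCN(c3cc(=O)c4cc(C(F)(F)F)cc([N+](=O)[O-])c4s3)CC2)CC1)c1ccccc1`: > 64 ug/mL, a limit
compound 2 `CC(C)C(=O)OC1CCC(CN2CCN(c3cc(=O)c4cc(C(F)(F)F)cc([N+](=O)[O-])c4s3)CC2)CC1`: > 64 ug/mL, a limit
compound 3 `O=C(NC1CCC(CN2CCN(c3cc(=O)c4cc(C(F)(F)F)cc([N+](=O)[O-])c4s3)CC2)CC1)c1ccccc1`: 44.3 ug/mL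

Compound 3 is the only one of these with a true number. Compounds 1 and 2 both rest at the limit of > 64 ug/mL in this assay, at which 2 of the 3 values shown sit.

Compound 4 `O=C(OC1CCC(CN2CCN(c3cc(=O)c4cc(C(F)(F)F)cc([N+](=O)[O-])c4s3)CC2)CC1)c1ccncc1` departs from compound 3 as follows: ((pyridin-4-yl)carbonyl)oxy in place of benzamido on a saturated ring carbon. Here ((pyridin-4-yl)carbonyl)oxy stands in place of benzamido on a saturated ring carbon, so the entering group has the carbonyl-oxy link shared by the benzoyloxy of compound 1 and the (isopropylcarbonyl)oxy of compound 2.

Going by the values given here, two measured steps bear on this change: an at least 1.4-fold lower number from compound 1 to compound 3 (0.15 log units; that floor lies within the scatter), and an at least 1.4-fold lower number from compound 2 to compound 3 (0.15 log units; that floor lies within the scatter). Both arrive at benzamido, so leaving it should point the opposite way, though neither floor clears the scatter. The third step, a step that the two limits leave unreadable from compound 1 to compound 2, gives no size.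

The expected step is a 1.6-fold higher number from compound 3 to compound 4 (0.20 log units; within the scatter), a modest upward one, and a report of only a limit is quite possible. For compound 4 the estimated value in this assay is 70 ug/mL, with an expected range of 35 ug/mL to 140 ug/mL.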

Compound 4, half-maximal inhibitory concentration: > 64 ug/mL
Compound 4: no number, only a limit; the forecaster's own chance of this, stated with the estimate: 60%; the middle value lies beyond the limit too.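

In this assay, the carbonyl-oxy link on the saturated ring carbon now carries a third group, pyridin-4-yl, and compound 4 again gives only a limit: the limit of > 64 ug/mL in this assay, at which 3 of the 4 values shown sit.

The change from benzamido gives an at least 1.4-fold higher number from compound 3 to compound 4 (0.15 log units; that floor lies within the scatter), while the steps from compound 1 and from compound 2 to compound 4 cannot be read, each joining two limits. With phenyl, isopropyl and pyridin-4-yl on the carbonyl, all three esters stop at the limit and benzamido alone gives a number, a pattern that none of the four compounds goes against, though its floor does not clear the scatter.

From the compounds shown here alone, how far the three esters really lie from compound 3 or from one another remains open. So does whether the number of compound 3 follows the amide link or its phenyl ring, a question that a pyridin-4-yl amide or a free amine on the same ring carbon would bear on.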